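Replacing an Aromatic Amide Group with Isopropyl

The source may report more compounds than this note shows. Statements on the series, on what has been measured and on what is new or still open speak of the compounds shown alone.

Measured in an in vitro ADME assay on microsomes from liver (Mus musculus) for pharmacokinetics, read by LC-MS, with a stated time of 10 min, tested at 1 uM; on this read-out lower numbers stand for slow clearance and higher numbers for fast clearance:
compound 1 `CN1C[C@H](C(=O)Nc2ccc(F)cc2)[C@@H](c2ccc(/C=C/C(=O)Nc3ccccc3N)cc2)C1`: 34 mL/min/kg
compound 2 `Cc1ccc(NC(=O)[C@H]2CN(C)C[C@@H]2c2ccc(/C=C/C(=O)Nc3ccccc3N)cc2)cn1`: 57 mL/min/kg
compound 3 `CN1C[C@H](C(=O)Nc2ccc(Cl)cn2)[C@@H](c2ccc(/C=C/C(=O)Nc3ccccc3N)cc2)C1`: 31 mL/min/kg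

Compound 3 gives 31 mL/min/kg, and the other two compounds do not separate from it: the data show a 1.1-fold lower number from compound 1 to compound 3 (0.04 log units; within the scatter) and a 1.8-fold lower number from compound 2 to compound 3 (0.26 log units; within the scatter). Compound 4 `CC(C)NC(=O)[C@H]1CN(C)C[C@@H]1c1ccc(/C=C/C(=O)Nc2ccccc2N)cc1` has not yet been measured. It differs from compound 3 at one place, with isopropyl in place of 5-chloropyridin-2-yl on an amide-type nitrogen.

All three measured steps change the group on this same nitrogen, the third being a 1.7-fold higher number from compound 1 to compound 2 (0.22 log units; within the scatter). Each of them exchanges one ring-bearing group for another, however. For the measured compounds named here, no measured compound has a group without a ring at this place, so the data offer only indirect guidance for this change, and the range must stay wide. Resting on a 1.1-fold lower number from compound 1 to compound 3 (0.04 log units; within the scatter) and a 1.8-fold lower number from compound 2 to compound 3 (0.26 log units; within the scatter), no shift beyond the scatter is expected in this assay, and no direction can be firmly favoured. The expected change is a 1.2-fold higher number from compound 3 to compound 4 (0.09 log units; within the scatter). The estimated clearance for compound 4 is 38 mL/min/kg, with an expected range of 17 mL/min/kg to 80 mL/min/kg.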

Compound 4, clearance: 12 mL/min/kg
Compound 4: the middle estimate sits 3.2-fold (0.50 log units) above what was measured; measured number outside the range, below it.
By their numbers in this assay, from the lowest: compound 4; then compounds 3, 1 and 2 (each within the scatter of the next).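

For the compounds shown here, the three ring-bearing groups on this amide-type nitrogen, 4-fluorophenyl, 6-methylpyridin-3-yl and 5-chloropyridin-2-yl, did not separate from one another, whereas isopropyl, the only group here without a ring, stands apart from all three in this assay with a 2.6-fold lower number from compound 3 to compound 4 (0.41 log units; beyond the scatter) and also a 2.8-fold lower number from compound 1 to compound 4 (0.45 log units; beyond the scatter) and a 4.8-fold lower number from compound 2 to compound 4 (0.68 log units; beyond the scatter) on the same nitrogen. The clearance read-out at this place therefore does respond to the group it carries, which the exchanges among ring-bearing groups alone could not show, and all three new steps run in the same direction, with no compound shown going against them. Nothing available explains this shift, and no measurement on the compounds bears on its origin.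

With a single ring-free group, the compounds shown leave open whether the lower number goes with the absence of an aromatic ring in general or with isopropyl in particular. A cyclohexyl group, a tert-butyl group or a longer chain such as n-butyl at this place would help to separate those two readings.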